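Buffer half-life notes: from compound 3 to compound 4

A few compounds are considered here, and "the series" means these few. Any claim that something is new, unique, unknown or untested is made for them only; others in the source may bear on it.

Measured compounds:
Compound 1 `C=CC(=O)Oc1cc(C(F)(F)F)cc(C(F)(F)F)c1`: in an ADME assay for pharmacokinetics, read by LC-MS, in phosphate buffer, with a stated time of 72 h, at pH 7.4, tested at 250 uM (a higher number here means that the compound lasts longer, a lower number that the compound disappears faster), compound 1 gives < 0.017 h, which is a limit of the assay.
Compound 2 `O=C1C=CC(=O)N1c1cc(C(F)(F)F)cc(C(F)(F)F)c1`: in this assay compound 2 gives < 0.017 h, again a limit.
Compound 3 `N#Cc1cc(C(F)(F)F)cc(C(F)(F)F)c1`: in this assay compound 3 gives > 50 h, also a limit, at the upper end.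

Compound 3 thus stands at the top of the three values shown, at the limit of > 50 h in this assay, at which 1 of the 3 values shown sits, while compounds 1 and 2 both sit at the limit of < 0.017 h in this assay, at which 2 of the 3 values shown sit. The step that the two limits leave unreadable from compound 1 to compound 2 has no readable size, both ends being limits. The step of an at least 2900-fold higher number from compound 1 to compound 3 (3.46 log units; beyond the scatter) and the step of an at least 2900-fold higher number from compound 2 to compound 3 (3.46 log units; beyond the scatter) are the two that can be sized, and each is large.

Compound 4 `O=C(CBr)c1cc(C(F)(F)F)cc(C(F)(F)F)c1` differs from compound 3 by (bromomethyl)carbonyl in place of cyano on an aromatic carbon. This change brings back a carbonyl and a double bond outside aromatic rings, features that compounds 1 and 2 carry and compound 3 lacks, and the two large measured steps ran in the direction of losing such groups. The step from compound 3 to compound 4 is therefore expected to go downward, an at least 5.0-fold lower number from compound 3 to compound 4 (0.69 log units; beyond the scatter), though not necessarily to the lower limit, since the entering group is not the same as those of compounds 1 or 2. The expected value for compound 4 is 10 h, with a range of 1 h to 50 h.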

Compound 4, half-life: < 0.017 h
Compound 4: a limit, no number (the forecaster's own chance of this, stated with the estimate: 25%); middle value at least 580-fold (2.76 log units) away from the limit.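

In this assay compound 4 gives < 0.017 h, a limit of the assay, so the lower limit is now reached with a third group on this aromatic carbon. The change of cyano to (bromomethyl)carbonyl gives an at least 2900-fold lower number from compound 3 to compound 4 (3.46 log units; beyond the scatter), which shows that the short half-life is not confined to the (vinylcarbonyl)oxy group of compound 1 or the five-membered ring of compound 2, and that it also appears with a group that has no ring and no ring-bound nitrogen or ester oxygen. The steps to compound 4 from compound 1 and from compound 2 cannot be read, both ends being limits, so no order can be given among these three compounds, and the lower limit now holds most of the series: the limit of < 0.017 h in this assay, at which 3 of the 4 values shown sit.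

Open, on these data alone, is whether the carbonyl or the bromine of (bromomethyl)carbonyl goes with the short half-life, a question that a plain acetyl group on the same carbon would address. Also open, as far as these compounds go, is what lies between the two limits, as no value shown falls inside the readable range, and whether an amine or a carboxylic acid at this carbon would give a readable half-life remains unknown.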